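The source may report more compounds than this note shows. Statements on the series, on what has been measured and on what is new or still open speak of the compounds shown alone.

Compound 1 `Clc1ccc(NCc2cn(-c3ccccc3)nc2-c2ccc(Br)cc2)cc1` gives 43000 nM; > 100000 nM (2 entries) in an ADME assay on Vero 76 cells (Chlorocebus sabaeus) for cytotoxicity, read by MTT assay, with a stated time of 96 h; on this read-out lower numbers stand for higher toxicity in this test and higher numbers for lower toxicity in this test.
Compound 2 `Cc1ccc(NCc2cn(-c3ccccc3)nc2-c2ccc(Br)cc2)cc1` gives > 100000 nM, a limit of the test and not a number.
Compound 3 `Brc1ccc(NCc2cn(-c3ccccc3)nc2-c2ccc(Br)cc2)cc1` gives 88000 nM.

Compound 2 thus stands at the limit of > 100000 nM in this assay, at which 1 of the 3 values shown sits. The unmeasured compound 4 `Cc1ccc(NCc2cn(-c3ccccc3)nc2-c2ccc(C(F)(F)F)cc2)cc1` differs from compound 2 by trifluoromethyl in place of bromo on an aromatic carbon. Among the measured compounds shown here, the only measured step, an at least 1.1-fold lower number from compound 2 to compound 3 (0.05 log units; that floor lies within the scatter), concerns a different exchange, bromo in place of methyl, and lies within the scatter; no measured step touches a trifluoromethyl. With all three measured compounds at or near the top of the tested range, no step beyond the scatter is expected, an at least 1.1-fold lower number from compound 2 to compound 4 (0.04 log units; that floor lies within the scatter). Compound 4 is therefore estimated at 90000 nM, between 40000 nM and 200000 nM, with a fair chance that this assay again reports only a limit.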

Compound 4, half-maximal cytotoxic concentration: 82000 nM
The estimate for compound 4 lay 1.1-fold (0.04 log units) above the measured number; the range from low to high includes it.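

In this assay, trifluoromethyl in place of bromo on the ring gives an at least 1.2-fold lower number from compound 2 to compound 4 (0.08 log units; that floor lies within the scatter). This is the first change shown at this position, and its true size stays unknown because compound 2 carries only a limit: the limit of > 100000 nM in this assay, at which 1 of the 4 values shown sits. What can be said is that 4 heavy atoms in place of 1 here produce no step that can be shown to exceed the scatter.

From the compounds shown here alone, whether an amine, a carboxylic acid or a longer chain at this position would move the number further remains open. Small differences are also hard to read at this end of the range, as repeat entries for compound 1 show: the several entries of compound 1 in this assay, 43000 nM; > 100000 nM (2 entries)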